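Extending the chain of compound 1 by octyl

A few compounds are considered here, and "the series" means these few. Any claim that something is new, unique, unknown or untested is made for them only; others in the source may bear on it.

Among the compounds with values here, in an ADME assay on HEK293 cells (Homo sapiens) for inhibition, read by MTT assay, with stated times of 18 h and 4 h (on this read-out lower numbers stand for stronger inhibition and higher numbers for weaker inhibition), compound 1 `CCCCCCCCOP(=O)(O)OCCSC(=S)N1CCCC1` gives 28300 nM and holds the only true number so far. Compound 2 `CCCCCCCCOP(=O)(O)OCCSC(=S)N1CCCCCC1` reads > 100000 nM as a limit of the assay and not a number. Within the data shown here, the single measured step, an at least 3.5-fold higher number from compound 1 to compound 2 (0.54 log units; beyond the scatter), lies beyond the scatter, and it concerns the group on a thiocarbonyl carbon, leaving the chain unchanged.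

Compound 3 `CCCCCCCCCCCCCCCCOP(=O)(O)OCCSC(=S)N1CCCC1` keeps the core of compound 1 and carries one change: octyl in place of hydrogen on a saturated chain carbon, eight bonds along the chain from an oxygen on an unsaturated carbon. That measured step therefore bears on this change only indirectly. It shows that one change in compound 1 can move this assay clearly, but it gives no direction for a chain change. Among the measured compounds shown here, no measured pair varies the chain, so the direction is a judgement with a wide margin. The expected change is a 2.4-fold lower number from compound 1 to compound 3 (0.37 log units; beyond the scatter) and is estimated as modest, towards a lower number, though a step within the scatter remains possible. Compound 3 is estimated at 12000 nM with an expected range of 2500 nM to 60000 nM for this compound.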

Compound 3, half-maximal inhibitory concentration: > 100000 nM
Compound 3: only a limit was reported (the forecaster's own chance of this, stated with the estimate: 12%); at least 8.3-fold (0.92 log units) between middle value and limit.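

In this assay the chain position now has a measured step: octyl in place of hydrogen on a saturated chain carbon, eight bonds along the chain from an oxygen on an unsaturated carbon, gives an at least 3.5-fold higher number from compound 1 to compound 3 (0.54 log units; beyond the scatter). Within the data shown here, this is the first reading for a chain change, and it points towards weaker inhibition; for compound 3 the reported > 100000 nM is a limit and not a number, so the step has a lower bound but no full size. Lengthening the chain and replacing pyrrolidin-1-yl with azepan-1-yl, each taken from compound 1, both end at the same limit, so neither change can be ranked against the other: the limit of > 100000 nM in this assay, at which 2 of the 3 values shown sit.

As far as these compounds go, it remains open whether a decyl or dodecyl chain on the core of compound 1 would still give a true number in this assay, or whether a hexyl chain would give a lower number than compound 1 at 28300 nM. Also open, from the compounds shown here alone, is how piperidin-1-yl on the thiocarbonyl carbon, with the octyl chain kept, would read.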